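This account rests on a few compounds, and the source may have more. Where it says the series, first, only, none or still open, it means among the compounds named here.

Measured so far in a functional assay on HepG2 cells (Homo sapiens) for inhibition, read by MTT assay, with a stated time of 72 h; a lower number here means a stronger inhibitor, a higher number a weaker inhibitor:
compound 1 `O=C1/C(=C\c2ccccc2)c2c(ncn2COCc2ccccc2)CCN1Cc1ccccc1` gives 13900 nM
compound 2 `O=C1/C(=C\c2ccccc2)c2c(ncn2COCc2ccccc2)CCN1Cc1ccc(F)cc1` gives 39400 nM
compound 3 `COc1ccc(CN2CCc3ncn(COCc4ccccc4)c3/C(=C/c3ccccc3)C2=O)cc1` gives 44400 nM

Compound 3 shares the high end of these three numbers with compound 2, as a 1.1-fold higher number from compound 2 to compound 3 (0.05 log units; within the scatter) shows, and it stands clear of compound 1, as a 3.2-fold higher number from compound 1 to compound 3 (0.50 log units; beyond the scatter) shows.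

Next comes compound 4 `Cc1ccccc1CN1CCc2ncn(COCc3ccccc3)c2/C(=C/c2ccccc2)C1=O`, which has no value yet. Its difference from compound 3 is 2-methylphenyl in place of 4-methoxyphenyl on a saturated chain carbon bound to an amide-type nitrogen in a ring and, cut one bond further out, reads 4-methoxybenzyl to 2-methylbenzyl.

Two measured steps change the same benzyl group, and both are modest: a 2.8-fold higher number from compound 1 to compound 2 (0.45 log units; beyond the scatter) for fluoro and a 3.2-fold higher number from compound 1 to compound 3 (0.50 log units; beyond the scatter) for methoxy. Exchanging one of these groups for the other gave a 1.1-fold higher number from compound 2 to compound 3 (0.05 log units; within the scatter) and so no change beyond the scatter. Going by the values given here, no measured compound carries a methyl group, so the data do not cover this substituent directly.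

Compound 4 keeps a substituted benzyl group, so its number is expected to lie near those of compound 2 (39400 nM) and compound 3 (44400 nM), with some allowance toward compound 1 (13900 nM). The expected step is a 1.5-fold lower number from compound 3 to compound 4 (0.17 log units; within the scatter) and thus slightly downward, with nothing beyond the scatter anticipated. For compound 4 the estimate is 30000 nM with an expected range from 12000 nM to 70000 nM in this assay for now.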

Compound 4, half-maximal inhibitory concentration: 53300 nM
Estimate against measurement, compound 4: 1.8-fold (0.25 log units) below; the measured number falls inside the stated range.
By their numbers in this assay, from the lowest: compound 1; then compounds 2, 3 and 4 (each within the scatter of the next).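

In this assay, a 1.2-fold higher number from compound 3 to compound 4 (0.08 log units; within the scatter) and a 1.4-fold higher number from compound 2 to compound 4 (0.13 log units; within the scatter), so at this position on the saturated chain carbon bound to an amide-type nitrogen in a ring, 2-methylphenyl cannot be told apart from 4-methoxyphenyl or 4-fluorophenyl, even though it enters with no hydrogen-bond acceptor where 4-methoxyphenyl has one. With a 3.8-fold higher number from compound 1 to compound 4 (0.58 log units; beyond the scatter), all three substituted groups now stand apart from the unsubstituted phenyl of compound 1, and none of the compounds shown goes against this, though the reach of the pattern ends with these four compounds. Nothing available explains why the three substituted groups give such similar numbers.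

The compounds shown leave open whether the placing of a substituent on the phenyl ring matters, since the step to 2-methylphenyl changes both the group and its place, and a 4-methylphenyl would separate the two. Also open, as far as these compounds go, is whether an amine or a carboxylic acid on that ring, or a longer chain in place of the benzyl group, would stay with compounds 2, 3 and 4 or with compound 1.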